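A few compounds are considered here, and "the series" means these few. Any claim that something is new, unique, unknown or untested is made for them only; others in the source may bear on it.

Measured in a functional assay on U-87MG ATCC cells for cytotoxicity against U-87 MG (Homo sapiens), read by colorimetric assay and MTT assay; on this read-out lower numbers stand for stronger inhibition and higher numbers for weaker inhibition:
- compound 1 `CCN(CC)C(=O)Cn1c(=O)c(-c2ccc(OC)cc2)cc2c(OC)cc(OC)cc21`: 10000 nM
- compound 2 `COc1ccc(-c2cc3c(OC)cc(OC)cc3n(CC#N)c2=O)cc1`: 10000 nM
- compound 3 `COc1ccc(-c2cc3c(OC)cc(OC)cc3n(CCCC#N)c2=O)cc1`: 10000 nM

Compound 3 stands level with compound 1 and compound 2 at the digits given, so these values do not separate the three compounds.

The next compound is compound 4 `COc1ccc(-c2cc3c(OC)cc(OC)cc3n(CC(=O)O)c2=O)cc1`, which carries carboxy in place of 2-cyanoethyl on a saturated chain carbon bound to an aromatic nitrogen.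

Three measured steps change the same place: no change at the digits printed from compound 1 to compound 2 (within the scatter), no change at the digits printed from compound 1 to compound 3 (within the scatter) and no change at the digits printed from compound 2 to compound 3 (within the scatter). All three lie within the scatter, so none gives a measurable size or a direction. Within the data shown here, no measured compound carries carboxy at this place, which leaves the entering group itself untested. Among the measured compounds shown here, the only guide is therefore the flat result of these three steps, and no change beyond the scatter is expected in this assay. The expected step is no change at the digits printed from compound 3 to compound 4 (within the scatter). The estimated value for compound 4 is 10000 nM, with an expected range from 5000 nM to 20000 nM.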

Compound 4, half-maximal inhibitory concentration: 10000 nM
For compound 4 middle estimate and measured number coincide at the digits printed; the range from low to high includes it.
By their numbers in this assay, from the lowest: compounds 1, 2, 3 and 4 (each within the scatter of the next).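

Carboxy is the first group at this place on a saturated chain carbon bound to an aromatic nitrogen to carry a hydrogen-bond donor, and in this assay it gives no change at the digits printed from compound 3 to compound 4 (within the scatter). The read-out stays flat against the shorter nitrile as well, with no change at the digits printed from compound 2 to compound 4 (within the scatter), and the swap of diethylamino for hydroxy on a carbonyl carbon gives no change at the digits printed from compound 1 to compound 4 (within the scatter); the flat result therefore now extends across amide, nitrile and carboxylic acid ends on this chain. Nothing at hand explains this lack of separation.

Still open, on these data alone, is whether an aminoethyl or hydroxyethyl chain, or a simple benzyl group, at this place would separate from these four compounds. Also open, as far as these compounds go, is whether replacing the methoxy groups on the shared core would shift the read-out.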